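The source may hold more compounds than are shown below. What is called first, only, known or untested is meant among the compounds shown, and "the series" means these compounds.

Compound 1 `Cn1cc2c(Cl)nc(NC(=O)c3ccccc3)nc2n1` and compound 2 `CC(C)n1cc2c(Cl)nc(NC(=O)c3ccccc3)nc2n1` share one core. In an assay on CHO cells for displacement of a labelled ligand from adenosine receptor A3 (Homo sapiens), read by scintillation counting, with a stated time of 3 h (a higher number here means a weaker inhibitor, a lower number a stronger inhibitor), compound 1 gives 23600 nM, and compound 2 gives 12800 nM, so the step of a 1.8-fold lower number from compound 1 to compound 2 (0.27 log units; within the scatter) comes from the change (isopropyl in place of methyl on an aromatic nitrogen). Compound 3 `Cn1cc2c(Cl)nc(N)nc2n1` has a different core, and how the two cores differ is not broken down here. In this assay compound 3 gives only a limit, > 100000 nM, which is the limit of > 100000 nM in this assay, at which 1 of the 3 values shown sits. Compound 4 `CC(C)n1cc2c(Cl)nc(N)nc2n1` is not yet measured; it differs from compound 3 by isopropyl in place of methyl on an aromatic nitrogen, the same change seen between compound 1 and compound 2. Because a 1.8-fold lower number from compound 1 to compound 2 (0.27 log units; within the scatter) was within the scatter, the step of a number no higher from compound 3 to compound 4 (the limit leaves the size open) is also expected to be small. Since compound 3 gives only a limit, compound 4 is estimated at 100000 nM, most likely again reported only as a limit.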

Compound 4, inhibition constant: > 100000 nM
Compound 4 was reported as a limit; the forecaster's own chance of this, stated with the estimate: 70%; the middle value sits exactly at the limit.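

Compound 3 and compound 4 are both reported only as limits in this assay, so no step between them can be read: the limit of > 100000 nM in this assay, at which 2 of the 4 values shown sit.

The compounds shown leave open what size of effect, if any, isopropyl in place of methyl on an aromatic nitrogen has on the core of compound 3.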